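This account rests on a few compounds, and the source may have more. Where it says the series, first, only, none or still open, it means among the compounds named here.

Compound 1 `CCCC1(c2ccccc2)CC(=O)C(C(CC(=O)c2ccc(-c3ccc(Br)cc3)cc2)c2ccccc2)=C(O)O1` in a functional assay on SK-MEL-2 cells (Homo sapiens) for inhibition, with a stated time of 72 h (on this read-out lower numbers stand for stronger inhibition and higher numbers for weaker inhibition), gives > 10000 nM, which is a limit of the assay and not a number. Compound 2 `CCCC1(CCc2ccccc2)CC(=O)C(C2CC(c3ccc(-c4ccc(Br)cc4)cc3)Cc3ccccc32)=C(O)O1` in this assay gives > 10000 nM, likewise a limit. Both values shown sit at the limit of > 10000 nM in this assay, at which 2 of the 2 values shown sit; compound 2 therefore stands at the ceiling of this assay, and nothing in the numbers sets it apart from compound 1. Within the data shown here, no step between measured compounds that differ in one place is available. Compound 3 `CCCC1(CCc2ccccc2)CC(=O)C(C2CC(c3ccc(OCc4ccc(C(F)(F)F)cc4)cc3)Cc3ccccc32)=C(O)O1` differs from compound 2 by (4-(trifluoromethyl)benzyl)oxy in place of 4-bromophenyl on an aromatic carbon, in words: (4-(trifluoromethyl)benzyl)oxy in place of 4-bromophenyl on an aromatic carbon. With both measured values at the limit, nothing shown supports a move in either direction. For compound 3, the step expected in this assay is a step that the limit leaves unreadable from compound 2 to compound 3, none beyond the scatter. Compound 3 is expected to give 20000 nM in this assay, with a range from 5000 nM to 80000 nM, most likely reported as a limit once more.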

Compound 3, half-maximal inhibitory concentration: > 10000 nM
Compound 3 gave a limit, no number; the forecaster's own chance of this, stated with the estimate: 80%; the middle value lies beyond the limit too.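

In this assay compound 3 gives > 10000 nM, a limit and not a number. Among these compounds, no step from compound 2 to compound 3 can be read. The compounds shown leave open what number any of them would give, and which change would bring a readable value: the limit of > 10000 nM in this assay, at which 3 of the 3 values shown sit.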